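The source may report more compounds than this note shows. Statements on the series, on what has been measured and on what is new or still open speak of the compounds shown alone.

Series notes. Compound 3 `COc1cccc(CN(Cc2cccc(-c3cc[nH]n3)c2)C(=O)Nc2c(SC)cc(C)nc2SC)c1` is known in a functional assay on a cell-free system (plasma) with sterol O-acyltransferase, Soat (Rattus norvegicus) as the target (on this read-out higher numbers stand for an effect only at larger amounts of compound and lower numbers for an effect already at smaller amounts), only through a limit: compound 3 gives > 0.1 mg/kg. Compound 2 `COc1ccc(CN(Cc2cccc(-c3cc[nH]n3)c2)C(=O)Nc2c(SC)cc(C)nc2SC)cc1` also sits at a limit, giving < 0.1 mg/kg in this assay. Compound 1 `O=C(Nc1c(F)cc(F)cc1F)N(Cc1ccc(F)cc1)Cc1cccc(-c2cc[nH]n2)c1` likewise gives only a limit, < 0.32 mg/kg. Going by the values given here, the single measured step, a number no lower from compound 2 to compound 3 (the limit leaves the size open), therefore has no readable size; the limit of < 0.1 mg/kg in this assay, at which 1 of the 3 values shown sits, and the limit of > 0.1 mg/kg in this assay, at which 1 of the 3 values shown sits, bracket it without fixing it. Compound 4 `CSc1cc(C)nc(SC)c1NC(=O)N(Cc1ccc(F)cc1)Cc1cccc(-c2cc[nH]n2)c1` carries 4-fluorophenyl in place of 3-methoxyphenyl on a saturated chain carbon bound to an amide-type nitrogen. Among the compounds with values here, no measured step bears directly on this change; compound 1 shares the 4-fluorobenzyl group, and the limit of < 0.32 mg/kg in this assay, at which 1 of the 3 values shown sits, tells where compound 1 sits. The step from compound 3 to compound 4 is expected to be a step that the limit leaves unreadable from compound 3 to compound 4. Compound 4 is estimated in this assay at 0.15 mg/kg, between 0.03 mg/kg and 0.6 mg/kg.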

Compound 4, dose for half-maximal effect: < 0.1 mg/kg
Compound 4: no number, only a limit; the forecaster's own chance of this, stated with the estimate: 60%; middle value at least 1.5-fold (0.17 log units) from the limit.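

In this assay, 4-fluorobenzyl in place of 3-methoxybenzyl on a saturated chain carbon bound to an amide-type nitrogen gives a number no higher from compound 3 to compound 4 (the limit leaves the size open), which fixes a direction but no size. Compound 4 gives < 0.1 mg/kg, a limit and not a number, so this position also tolerates a benzyl group carrying fluoro rather than methoxy on the core of compounds 2 and 3: the limit of < 0.1 mg/kg in this assay, at which 2 of the 4 values shown sit.

The steps from compound 2 to compound 4 and from compound 1 to compound 4 cannot be read. As far as these compounds go, how a carboxylic acid or an amine in place of the fluoro group would read in this assay remains open.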